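The compounds below may be only part of what the source reports. "The series", "measured", "known", "first", "only" and "open" are said of these compounds alone.

Measured in a functional assay on MCF7 cells (Homo sapiens) for inhibition, read by MTT assay, with a stated time of 72 h; on this read-out higher numbers stand for weaker inhibition and lower numbers for stronger inhibition:
- Compound 1 `FC(F)(F)c1ccc(CSc2nc(N3CCN(c4ccccc4)CC3)cc(C(F)(F)F)n2)cc1`: > 50000 nM, a limit
- Compound 2 `FC(F)(F)c1ccc(CSc2nc(N3CCN(c4ccccn4)CC3)cc(C(F)(F)F)n2)cc1`: > 50000 nM, a limit
- Compound 3 `Cc1csc(Sc2cc(C(F)(F)F)nc(SCc3ccc(C(F)(F)F)cc3)n2)n1`: 14500 nM

For the measured compounds named here, compound 3 holds the only actual number, since the other two results are the limit of > 50000 nM in this assay, at which 2 of the 3 values shown sit. Compound 4 `Cc1nnc(Sc2cc(C(F)(F)F)nc(SCc3ccc(C(F)(F)F)cc3)n2)s1` has 5-methyl-1,3,4-thiadiazol-2-yl in place of 4-methyl-1,3-thiazol-2-yl on a sulfur. Going by the values given here, the sole measured step, a step that the two limits leave unreadable from compound 1 to compound 2, concerns a different change and has no readable size, so no measured step bears on this one. No shift beyond the scatter is therefore expected in this assay, and no direction can be assigned. The expected step is a 1.0-fold higher number from compound 3 to compound 4 (0.01 log units; within the scatter). Compound 4 is estimated at 15000 nM, within an expected range of 6000 nM to 40000 nM.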

Compound 4, half-maximal inhibitory concentration: > 50000 nM
Compound 4: a limit, no number; the forecaster's own chance of this, stated with the estimate: 20%; middle value at least 3.3-fold (0.52 log units) from the limit.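

In this assay, the step between compound 1 and compound 2 cannot be read, but the change on the sulfur gives an at least 3.4-fold higher number from compound 3 to compound 4 (0.53 log units; beyond the scatter). The result for compound 4 is a limit, so this step has a minimum size and no exact one. The position on the sulfur thus responds to the identity of the five-membered aromatic ring, and compound 3 remains the only compound with a number: the limit of > 50000 nM in this assay, at which 3 of the 4 values shown sit.

Going by these compounds, it remains open whether a 1,3-oxazol-2-yl on that sulfur would give a number in this assay. Also open, on these data alone, is how a carboxylic acid in place of the methyl on the 1,3-thiazol-2-yl would read.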